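The compounds below may be only part of what the source reports. "The series", "measured", "known", "first", "only" and "open" are said of these compounds alone.

Working notes on the series. Compound 2 `O=Cc1ccc(-c2cncc(Cl)c2N2CCC3(CCNC3=O)CC2)o1` gives the highest number of the three measured in a functional assay on MV4-11 cells (Homo sapiens) for inhibition, read by resazurin assay, with a stated time of 72 h (on this read-out lower numbers stand for stronger inhibition of growth and higher numbers for weaker inhibition of growth), at 5190 nM. Compound 3 `O=C1NCCC12CCN(c1c(Cl)cncc1-c1ccc(CN3CCCC3)s1)CC2` gives 3370 nM in this assay, a value within the scatter of compound 2. Compound 1 `O=C1NCCC12CCN(c1c(Cl)cncc1-c1ccoc1)CC2` gives 750 nM, the lowest of the three. Compound 4 `Cn1cc(-c2cncc(Cl)c2N2CCC3(CCNC3=O)CC2)cn1` is not yet measured; it differs from compound 2 as follows: 1-methyl-1H-pyrazol-4-yl in place of 5-formylfuran-2-yl on an aromatic carbon.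

Going by the values given here, the one measured step that bears on this change is a 6.9-fold higher number from compound 1 to compound 2 (0.84 log units; beyond the scatter), where 5-formylfuran-2-yl replaced furan-3-yl on an aromatic carbon. Taking 5-formylfuran-2-yl away again and putting another small five-membered aromatic ring, 1-methyl-1H-pyrazol-4-yl, in its place is expected to run in the opposite direction; no measured pair shows 1-methyl-1H-pyrazol-4-yl itself, so the size is uncertain. In this assay compound 4 is therefore expected to give a lower number, estimated at 1100 nM with a range from 400 nM to 3200 nM. That estimate amounts to an expected step of a 4.7-fold lower number from compound 2 to compound 4 (0.67 log units; beyond the scatter).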

Compound 4, concentration for 50% growth inhibition: 5530 nM
Compound 4: the middle estimate sits 5.0-fold (0.70 log units) below what was measured, and the stated range ends below it.
By their numbers in this assay, from the lowest: compound 1; then compounds 3, 2 and 4 (each within the scatter of the next).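

In this assay, the exchange gives a 1.1-fold higher number from compound 2 to compound 4 (0.03 log units; within the scatter), so at this position 1-methyl-1H-pyrazol-4-yl and 5-formylfuran-2-yl cannot be told apart, although they differ in ring hetero atoms and in the double bond outside the aromatic ring. A five-membered aromatic ring without a formyl group therefore does not by itself give the lower number of compound 1, as a 7.4-fold higher number from compound 1 to compound 4 (0.87 log units; beyond the scatter) shows, a step that stands alongside a 6.9-fold higher number from compound 1 to compound 2 (0.84 log units; beyond the scatter). Nothing available explains why furan-3-yl separates from these two groups.

Still open, on these data alone, is whether the nitrogen atoms or the methyl group separate compound 4 from compound 1, since the two groups differ in both. The compounds shown also leave open how a phenyl ring, or a carboxylic acid on the five-membered ring, would read at this position.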